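The source may hold more compounds than are shown below. What is called first, only, known or untested is meant among the compounds shown, and "the series" means these compounds.

Measured compounds:
- compound 1, `OC[C@H]1O[C@H](Oc2ccc(-c3ccc(Cl)c(Cl)c3)cc2Cl)[C@@H](O)[C@@H](O)[C@@H]1O`: "not determined" (no result reported)
- compound 2, `N#Cc1ccc(-c2ccc(O[C@H]3O[C@H](CO)[C@@H](O)[C@H](O)[C@@H]3O)c(Cl)c2)cc1`: 2.1

For the measured compounds named here, only two compounds have been through the work so far, and only one of them carries a number. Compound 1 has no reported result. Going by the values given here, in a physicochemical assay for lipophilicity, read by LC-MS, measured as octanol-water partition, with a stated time of 2 h, at pH 7.4, tested at 1 uM (on this read-out lower numbers stand for lower lipophilicity and higher numbers for higher lipophilicity), compound 2 gives 2.1, which makes it the only compound with a number on this read-out and therefore the single point of reference.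

Compound 3, `CC(=O)c1ccc(-c2ccc(O[C@H]3O[C@H](CO)[C@@H](O)[C@H](O)[C@@H]3O)c(Cl)c2)cc1`, has not yet been measured. It differs from compound 2 in one place: acetyl in place of cyano on an aromatic carbon

Among the compounds with values here, no step between two measured compounds is available to calibrate this change, so the expectation rests on compound 2 alone. The step from compound 2 to compound 3 is expected to be small, within the scatter, with no clear direction; the expected step is no change at the digits printed from compound 2 to compound 3 (within the scatter). Compound 3 is therefore estimated at 2.1, with a range from 1.7 to 2.5.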

Compound 3, distribution coefficient: 2.1
Compound 3: the middle estimate sits on the measured number at the digits printed; the range from low to high includes it.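

Replacing cyano with acetyl on this aromatic carbon, para to a large group, gives no change at the digits printed from compound 2 to compound 3 (within the scatter) in this assay on the shared core. With compound 1 lacking a number and compound 2 standing alone, no earlier comparison could show how this read-out responds to a change at this position, and this pair provides the first such reading: a triple bond outside the aromatic rings gives way to a double bond, and the two groups cannot be told apart here. No supporting measurement is available to explain this outcome.

On these data alone, whether an amine or a carboxylic acid at this position would shift the read-out beyond the scatter remains open. A single step also cannot show whether a longer chain such as butyryl would behave as acetyl does.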